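This account rests on a few compounds, and the source may have more. Where it says the series, first, only, none or still open, it means among the compounds named here.

The three measured compounds are:
compound 1 `N#C/C=C/c1cc(F)c(Oc2nc(Nc3ccc(C#N)c(F)c3)nc3ccsc23)c(F)c1` with 96000 nM
compound 2 `N#C/C=C/c1cc(F)c(Oc2nc(Nc3ccc(C#N)nc3)nc3ccsc23)c(F)c1` with 47500 nM
compound 3 `Cc1cc(-c2ccc(F)cc2)cc(C)c1Oc1nc(Nc2ccc(C#N)c(F)c2)nc2sccc12` with 28900 nM

All three were tested in a toxicity assay on MT4 cells (Homo sapiens) for cytotoxicity, read by MTT assay, with a stated time of 5 days; on this read-out lower numbers stand for higher toxicity in this test and higher numbers for lower toxicity in this test. Compound 1 and compound 2 share one core and differ in a single place: 6-cyanopyridin-3-yl in place of 4-cyano-3-fluorophenyl on a nitrogen on an aromatic ring This change gave a 2.0-fold lower number from compound 1 to compound 2 (0.31 log units; beyond the scatter). Compound 3 rests on another core; the difference between the core of compound 3 and the core of compound 1 is not broken down here. Against compound 1, compound 3 gives a lower number in this assay, while against compound 2 the two numbers lie within the usual scatter of each other, so no order can be read between them.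

Compound 4 `Cc1cc(-c2ccc(F)cc2)cc(C)c1Oc1nc(Nc2ccc(C#N)nc2)nc2sccc12` has not yet been measured. It relates to compound 3 as compound 2 relates to compound 1: 6-cyanopyridin-3-yl in place of 4-cyano-3-fluorophenyl on a nitrogen on an aromatic ring The place of the change is the same in both pairs, so this is the same change carried onto the second core. If it acts on the core of compound 3 as it did on the core of compound 1, compound 4 is expected to show a 1.9-fold lower number from compound 3 to compound 4 (0.28 log units; within the scatter) in this assay, an expectation resting on the single measured instance a 2.0-fold lower number from compound 1 to compound 2 (0.31 log units; beyond the scatter). The change has been seen only once, and on a different core, so the expectation is uncertain. Compound 4 is therefore estimated at 15000 nM, with a range from 7000 nM to 35000 nM.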

Compound 4, half-maximal cytotoxic concentration: 2230 nM
Compound 4: the middle estimate sits 6.7-fold (0.83 log units) above what was measured; measured number outside the range, below it.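

In this assay, putting 6-cyanopyridin-3-yl in place of 4-cyano-3-fluorophenyl on the nitrogen gave a 13-fold lower number from compound 3 to compound 4 (1.11 log units; beyond the scatter), so the number fell on both cores, but the two steps differ in size: the same change on two cores in this assay, a 2.0-fold lower number (0.31 log units; beyond the scatter) from compound 1 to compound 2 and a 13-fold lower number (1.11 log units; beyond the scatter) from compound 3 to compound 4, 6.4-fold (0.81 log units) apart, beyond the scatter of two such steps

In these two pairs, the direction of the change carried from the core of compound 1 to the core of compound 3, whereas its size did not, so the step measured on one core gave a poor guide to the size of the step on the other. This does not show which feature of the two cores sets the gap, as they differ in more than one place, and two pairs do not establish a rule for any third core.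

The compounds shown leave open how other groups on that nitrogen would read in this assay, for example a plain phenyl ring or a pyridine ring carrying a carboxylic acid or an amine instead of the nitrile. They also leave open whether the larger step would recur on further cores, or whether the step seen from compound 1 to compound 2 would prove the more usual size.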